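Methyl to Trifluoromethyl: an Expected Cytotoxicity for Compound 3

The source may report more compounds than this note shows. Statements on the series, on what has been measured and on what is new or still open speak of the compounds shown alone.

Measured compounds:
compound 1, `COc1ccc(N/C(CCNC2=CC(=O)c3ccccc3C2=O)=N\S(=O)(=O)c2ccc(C)cc2)cc1`: 25500 nM
compound 2, `Cc1ccc(S(=O)(=O)/N=C(/CCNC2=CC(=O)c3ccccc3C2=O)Nc2cccc(C)c2)cc1`: 18700 nM

Both compounds share one core and differ only in the ring carried on an amine nitrogen. In a functional assay on A549 cells (Homo sapiens) for cytotoxicity, read by MTT assay, with a stated time of 48 h (a lower number here means a stronger inhibitor, a higher number a weaker inhibitor), compound 1 gives 25500 nM and compound 2 gives 18700 nM. Among the compounds with values here, the single step recorded here, a 1.4-fold lower number from compound 1 to compound 2 (0.13 log units; within the scatter), stays within the scatter, so compound 2 stands with the lower of two numbers, but not in a way that separates it from compound 1.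

Compound 3, `Cc1ccc(S(=O)(=O)/N=C(/CCNC2=CC(=O)c3ccccc3C2=O)Nc2cccc(C(F)(F)F)c2)cc1`, follows from compound 2 by one change: trifluoromethyl in place of methyl on an aromatic carbon. Within the data shown here, no measured step touches a trifluoromethyl group; the only comparison available, from compound 1 to compound 2, swapped one small ring substituent for another and moved the number by less than the scatter. On that basis the step from compound 2 to compound 3 in this assay is expected to be small, with no direction that can be called beyond the scatter: the estimated step is a 1.2-fold lower number from compound 2 to compound 3 (0.10 log units; within the scatter).

For compound 3 the expected value in this assay is 15000 nM, within a range from 6000 nM to 40000 nM.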

Compound 3, half-maximal inhibitory concentration: 78500 nM
Estimate against measurement, compound 3: 5.2-fold (0.72 log units) below; the measured number lies above the stated range.
By their numbers in this assay, from the lowest: compounds 2 and 1 (each within the scatter of the next); then compound 3.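

In this assay the group at this place on the ring does matter: trifluoromethyl in place of methyl on an aromatic carbon gives a 4.2-fold higher number from compound 2 to compound 3 (0.62 log units; beyond the scatter) and so moves the number toward a weaker inhibitor, which the step between the two earlier compounds, lying within the scatter, could not show. Set against the other earlier compound, 3-(trifluoromethyl)phenyl in place of 4-methoxyphenyl on an amine nitrogen gives a 3.1-fold higher number from compound 1 to compound 3 (0.49 log units; beyond the scatter) and points the same way, so compound 3 stands apart from both earlier compounds, although that comparison changes the substituent and where it sits together. No information is available on what lies behind this loss of activity in the cells.

With only methyl and trifluoromethyl to compare at this place, a single change says little about how the number follows the group, and a chlorine atom, a hydroxyl group or an amine there could fall near either compound. As far as these compounds go, it also remains open whether trifluoromethyl carries the same penalty on other parts of the molecule, such as the other aromatic ring on the sulfonyl group.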